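Working notes: hexyl in place of phenyl on the chain

The compounds below may be only part of what the source reports. "The series", "measured", "known", "first", "only" and "open" are said of these compounds alone.

Compound 1 `COc1ccc2c(c1)[n+]([O-])nc(NCOCc1ccccc1)[n+]2[O-]` and compound 2 `[O-][n+]1nc(NCOCc2ccccc2)[n+]([O-])c2ccccc21` share one core and differ in a single place. In a functional assay on A549 cells (Homo sapiens) for cytotoxicity, read by MTT assay, with a stated time of 72 h (on this read-out higher numbers stand for weaker inhibition and lower numbers for stronger inhibition), compound 1 gives 2500 nM, and compound 2 gives 10800 nM. Among the measured compounds shown here, the one step measured so far, a 4.3-fold higher number from compound 1 to compound 2 (0.64 log units; beyond the scatter), is hydrogen in place of methoxy on an aromatic carbon. Compound 2 thus stands at the higher of the two numbers, with compound 1 below it by a margin beyond the scatter.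

Compound 3 `CCCCCCCOCNc1n[n+]([O-])c2ccccc2[n+]1[O-]` keeps the core of compound 2 and changes another part: hexyl in place of phenyl on a saturated chain carbon bound to an oxygen on a saturated carbon. For the measured compounds named here, no measured step touches this part of the series; the only step at hand, from compound 1 to compound 2, concerns the aromatic carbon and says nothing about the chain. The expectation for compound 3 in this assay therefore rests on compound 2 alone, and the step of a 1.1-fold lower number from compound 2 to compound 3 (0.03 log units; within the scatter) is expected to fall within the scatter, in no clear direction. Compound 3 is expected to give 10000 nM, with a range from 3000 nM to 35000 nM.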

Compound 3, half-maximal inhibitory concentration: 2610 nM
Estimate against measurement, compound 3: 3.8-fold (0.58 log units) above; the whole stated range lies above it.
By their numbers in this assay, from the lowest: compounds 1 and 3 (each within the scatter of the next); then compound 2.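

Working notes: in this assay, the position on a saturated chain carbon bound to an oxygen on a saturated carbon responds to a single change, with hexyl in place of phenyl giving a 4.1-fold lower number from compound 2 to compound 3 (0.62 log units; beyond the scatter) and a modest step beyond the scatter. Until now, only the aromatic carbon had been seen to move the number, so this chain position is a second place in the series where one change counts. On the core of compound 2, the ring-free hexyl gives the lower number and the aromatic phenyl the higher one, although no available evidence accounts for the step.

The open question is whether the step follows from losing the aromatic ring or from the shape of the open chain, which cyclohexyl, with its saturated ring, and a longer chain such as octyl could help to separate on the same core. Also open, on these data alone, is whether hexyl and the methoxy group of compound 1 would act independently on one core, and whether a terminal amine or carboxylic acid on the chain would be tolerated.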